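Swapping a diethylamino for isobutylamino on a biguanide

The source may report more compounds than this note shows. Statements on the series, on what has been measured and on what is new or still open speak of the compounds shown alone.

Measured so far:
Compound 1, `CCN(CC)C(=N)NC(=N)Nc1ccc(F)c(F)c1`: 7800 nM
Compound 2, `CC(C)NC(=N)NC(=N)Nc1ccc(C(F)(F)F)cc1`: 3600 nM
Compound 3, `N=C(NC(=N)NC1CCCC1)Nc1ccc(F)cc1F`: 4000 nM

All three were tested in a functional assay on A549 cells (Homo sapiens) for antiproliferative activity, read by MTT assay, with a stated time of 72 h; a lower number here means a stronger inhibitor, a higher number a weaker inhibitor. Compound 1 sits at the top end of the three numbers: its value and that of compound 3 lie within the usual scatter of each other, so no order between them can be claimed, while compound 2 gives a number that lies beyond the scatter below compound 1.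

Compound 4, `CC(C)CNC(=N)NC(=N)Nc1ccc(F)c(F)c1`, has not been measured. It keeps the core of compound 1 and differs in one place: isobutylamino in place of diethylamino on a carbon with a double bond to nitrogen. Among the measured compounds shown here, with no pair of measured compounds differing in a single place, the size of this step cannot be read off directly. Compounds 2 and 3 both carry an amino group with one hydrogen on that carbon and both give lower numbers than compound 1, so a modest drop in the number, of a size at the edge of the scatter, is expected for compound 4 as step a 1.6-fold lower number from compound 1 to compound 4 (0.19 log units; within the scatter). The estimate for compound 4 is therefore 5000 nM, with a range from 2000 nM to 13000 nM.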

Compound 4, half-maximal inhibitory concentration: 2400 nM
Estimate against measurement, compound 4: 2.1-fold (0.32 log units) above; the measured number falls inside the stated range.
By their numbers in this assay, from the lowest: compounds 4, 2, 3 and 1 (each within the scatter of the next, the first and the last beyond it).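

Among the compounds shown here, the step in this assay from diethylamino to isobutylamino on a carbon with a double bond to nitrogen is a 3.3-fold lower number from compound 1 to compound 4 (0.51 log units; beyond the scatter) and gives the first direct reading of a single change at this place. The two groups hold the same heavy atoms and differ in their arrangement, with isobutylamino carrying a hydrogen-bond donor that diethylamino lacks, so this place responds to more than the count of carbon and nitrogen atoms. No measurement shown here gives a reason for the step.

Going by these compounds, it remains open whether the hydrogen on the amine nitrogen or the branching of the chain matters more, a question that a straight butylamino chain or a dipropylamino group could help to separate. The compounds shown also leave open whether the same step holds with a different group on the shared core.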